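Compound 3 Gives Up Its 1-methyl-1H-indol-5-yl Group

The source may hold more compounds than are shown below. What is called first, only, known or untested is meant among the compounds shown, and "the series" means these compounds.

Measured in a functional assay on MCF7 cells (Homo sapiens) for inhibition, read by CCK-8 assay, with a stated time of 48 h; a higher number here means a weaker inhibitor, a lower number a stronger inhibitor:
- compound 1 `COc1cc(-c2ccnc3cc(-c4c[nH]c5ccccc45)nn23)cc(OC)c1OC`: 85 nM
- compound 2 `COc1cc(-c2ccnc3cc(-c4ccc(Cl)cc4)nn23)cc(OC)c1OC`: 2320 nM
- compound 3 `COc1cc(-c2ccnc3cc(-c4ccc5c(ccn5C)c4)nn23)cc(OC)c1OC`: 3 nM

Compound 3 has the lowest number of the three. Compound 4 `COc1cc(-c2ccnc3cc(-c4ccc(C(C)=O)cc4)nn23)cc(OC)c1OC`, not yet measured, differs from it at one place: 4-acetylphenyl in place of 1-methyl-1H-indol-5-yl on an aromatic carbon. The closest measured parallel is a 770-fold lower number from compound 2 to compound 3 (2.89 log units; beyond the scatter), which exchanged 4-chlorophenyl for the same 1-methyl-1H-indol-5-yl. a 28-fold lower number from compound 1 to compound 3 (1.45 log units; beyond the scatter) also shows how much this position can matter. Compound 4 likewise loses that group for a substituted phenyl, so a large step to a higher number is expected in this assay, though perhaps a smaller one than the parallel. The estimated change is a 230-fold higher number from compound 3 to compound 4 (2.37 log units; beyond the scatter). For compound 4, the expected value is 700 nM, within an estimated range of 90 nM to 4000 nM.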

Compound 4, half-maximal inhibitory concentration: 5230 nM
Estimate against measurement, compound 4: 7.5-fold (0.87 log units) below; the whole stated range lies below it.
By their numbers in this assay, from the lowest: compound 3; then compound 1; then compound 2; then compound 4.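

In this assay, 4-acetylphenyl proves no better a replacement for the indole groups than 4-chlorophenyl: against 1-methyl-1H-indol-5-yl the step is a 1700-fold higher number from compound 3 to compound 4 (3.24 log units; beyond the scatter), and against 1H-indol-3-yl it is a 62-fold higher number from compound 1 to compound 4 (1.79 log units; beyond the scatter). Acetyl in place of chloro gives only a modest change, a 2.3-fold higher number from compound 2 to compound 4 (0.35 log units; beyond the scatter), so both substituted phenyl compounds stay far above both indole compounds. Nothing available explains these gaps. The compounds shown leave open whether an amine in place of acetyl on the phenyl ring would recover any strength. They also leave open whether an indol-5-yl group lacking the methyl would match compound 3.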